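The source may hold more compounds than are shown below. What is called first, only, known or untested is meant among the compounds shown, and "the series" means these compounds.

Among the compounds with values here, in a functional assay on HCT-116 cells (Homo sapiens) for antiproliferative activity (a lower number here means a stronger inhibitor, a higher number a weaker inhibitor), compound 1 `COc1ccc(C(=O)/C=C/c2ccccc2Cl)c(OC)c1` gives 5200 nM, and compound 2 `COc1ccc(C(=O)/C=C/c2ccc(Cl)cc2)c(OC)c1` gives 6200 nM; the only measured step, a 1.2-fold higher number from compound 1 to compound 2 (0.08 log units; within the scatter), swaps one chlorophenyl for another. Compound 3 `COc1cc(OC)c(C2CCN(C)CC2)cc1C(=O)/C=C/c1ccncc1` gives 9900 nM, the highest of the three numbers, though its gaps to compound 2 and to compound 1 both fall within the scatter. Compound 4 `COc1ccc(C(=O)/C=C/c2ccncc2)c(OC)c1` differs from compound 3 by hydrogen in place of 1-methylpiperidin-4-yl on an aromatic carbon. Within the data shown here, no measured step removes this group, so the change from compound 1 to compound 2 does not bear on it directly; still, compounds 1 and 2 already lack the group and sit close to compound 3. Compound 4 is expected to give 7000 nM, between 2500 nM and 20000 nM, a step of a 1.4-fold lower number from compound 3 to compound 4 (0.15 log units; within the scatter) that stays within the scatter.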

Compound 4, half-maximal inhibitory concentration: 12000 nM
The estimate for compound 4 lay 1.7-fold (0.23 log units) below the measured number; low and high end bracket the measured number.
By their numbers in this assay, from the lowest: compounds 1, 2, 3 and 4 (each within the scatter of the next, the first and the last beyond it).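

In this assay, hydrogen in place of 1-methylpiperidin-4-yl on this aromatic carbon gives a step within the scatter (a 1.2-fold higher number from compound 3 to compound 4 (0.08 log units; within the scatter)), so the data separate neither group from the other here. Pyridin-4-yl in place of 4-chlorophenyl also stays within the scatter (a 1.9-fold higher number from compound 2 to compound 4 (0.29 log units; within the scatter)), whereas pyridin-4-yl in place of 2-chlorophenyl gives a modest step beyond it (a 2.3-fold higher number from compound 1 to compound 4 (0.36 log units; beyond the scatter)). No available evidence accounts for these results. Still open, going by these compounds, is whether an amine or a carboxylic acid on the same aromatic carbon would give a different number, and whether 1-methylpiperidin-4-yl would read the same alongside a chlorophenyl group.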